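The source may hold more compounds than are shown below. What is called first, only, known or untested is meant among the compounds shown, and "the series" means these compounds.

Measured compounds:
compound 1 `CNC(=O)/C=C/c1ccncc1-c1ccc2ccccc2c1` — 12.4 nM
compound 2 `O=C(/C=C/c1ccncc1-c1ccc2[nH]ccc2c1)N1CCOCC1` — 190 nM
compound 3 `Cn1ncc2cc(-c3cnccc3/C=C/C(=O)O)ccc21` — 34.6 nM

All three numbers come from an assay on a protein complex for inhibition of CDK8/Cyclin C (Homo sapiens), with a stated time of 1 h; a lower number here means a stronger inhibitor, a higher number a weaker inhibitor. Compound 1 gives 12.4 nM, the lowest of the three. Compound 3 gives 34.6 nM, a higher number by a margin beyond the scatter. Compound 2 gives 190 nM, the highest of the set and the furthest from compound 1. No two of these compounds differ in one place only, so none of the gaps can be tied to a single change; the three differ both at the amide end and in the ring attached to the shared core.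

Compound 4 `CN(C)C(=O)/C=C/c1ccncc1-c1ccc2ccccc2c1` is not yet measured in this assay. Relative to compound 1 the change is methyl in place of hydrogen on an amide-type nitrogen. Going by the values given here, no measured pair shows this change on its own, so the size of the step has to be an expectation rather than a reading. Among the compounds with values here, the only compound carrying an amide with no hydrogen on its nitrogen, compound 2, also carries a different ring, and its 190 nM cannot be split into separate contributions. For compound 4 a step in this assay towards a higher number is expected, of moderate size, a 3.2-fold higher number from compound 1 to compound 4 (0.51 log units; beyond the scatter). Compound 4 is therefore estimated at 40 nM, with a range from 12 nM to 150 nM.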

Compound 4, half-maximal inhibitory concentration: 30.1 nM
Compound 4: the middle estimate sits 1.3-fold (0.12 log units) above what was measured; the measured number falls inside the stated range.
By their numbers in this assay, from the lowest: compound 1; then compounds 4 and 3 (each within the scatter of the next); then compound 2.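

In this assay the series now has its first step tied to a single change: methyl in place of hydrogen on the amide-type nitrogen gives a 2.4-fold higher number from compound 1 to compound 4 (0.39 log units; beyond the scatter) and this step is modest, though beyond the scatter. The amide hydrogen of compound 1 is therefore not essential at this position, since compound 4, with no hydrogen on that nitrogen, still gives 30.1 nM in this assay. No measurement on hand explains the rise in the number with this change.

Going by these compounds, it remains open whether a larger group on this nitrogen, such as ethyl, 2-hydroxyethyl or a 2-aminoethyl chain, would continue the modest rise or produce a sharper one. Going by these compounds alone, it also remains open whether the same methyl step holds when the ring on the shared core differs, as no pair with another ring isolates this change, and the separate contributions of the amide end and the ring to the number for compound 2 cannot yet be read.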